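Butyl to 4-methylphenyl on the ring nitrogen

A few compounds are considered here, and "the series" means these few. Any claim that something is new, unique, unknown or untested is made for them only; others in the source may bear on it.

Measured in a functional assay on MDA-MB-231 cells (Homo sapiens) for antiproliferative activity, read by MTT assay, with a stated time of 72 h; a lower number here means a stronger inhibitor, a higher number a weaker inhibitor:
compound 1 `CCCCn1ccnc1-c1cc(OC)c(OC)c(OC)c1` gives 70400 nM
compound 2 `COc1ccc(-n2ccnc2-c2cc(OC)c(OC)c(OC)c2)cc1[N+](=O)[O-]` gives 7500 nM

Compound 1 has the higher of the two numbers, and the gap to compound 2 lies beyond the scatter. Compound 3 `COc1cc(-c2nccn2-c2ccc(C)cc2)cc(OC)c1OC` has 4-methylphenyl in place of butyl on an aromatic nitrogen. Among the measured compounds shown here, no measured pair isolates this change. Compound 2, at 7500 nM, also carries a six-membered aromatic ring on that nitrogen, so a lower number beyond the scatter is expected in this assay, of similar size to that gap. The expected change is a 7.8-fold lower number from compound 1 to compound 3 (0.89 log units; beyond the scatter) in this estimate. For compound 3 the estimated value is 9000 nM (range 1500 nM to 40000 nM) in this assay.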

Compound 3, half-maximal inhibitory concentration: 4100 nM
The estimate for compound 3 lay 2.2-fold (0.34 log units) above the measured number, and the stated range covers the measured number.
By their numbers in this assay, from the lowest: compounds 3 and 2 (each within the scatter of the next); then compound 1.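

In this assay, among the compounds shown here, the change of butyl to 4-methylphenyl on the aromatic nitrogen gives a 17-fold lower number from compound 1 to compound 3 (1.23 log units; beyond the scatter), the first step that isolates this change at this position. This position of the shared core therefore responds strongly to the swap. No measurement at hand gives a reason for this step.

As far as these compounds go, whether the six-membered aromatic ring or simply the larger carbon group carries the change stays open, and a longer chain such as hexyl on this nitrogen could separate the two. From the compounds shown here alone, the effect of an amine or a carboxylic acid on the 4-methylphenyl ring also remains open.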